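The compounds below may be only part of what the source reports. "The series", "measured", "known", "first", "only" and "open" are said of these compounds alone.

Compound 1 `Cc1ccccc1N(C)C(=O)c1ccc(-c2ccc(OS(N)(=O)=O)cc2)o1` in an assay on T47D cells for inhibition of Steryl-sulfatase (Homo sapiens), read by HPLC, with a stated time of 24 h (on this read-out higher numbers stand for weaker inhibition and lower numbers for stronger inhibition), gives 28 nM, the highest of the three numbers shown, though all three lie within the scatter of one another: compound 2 `Cc1ccccc1N(C)C(=O)c1ccc(-c2ccc(OS(N)(=O)=O)c(Cl)c2)o1` gives 25 nM and compound 3 `Cc1ccccc1N(C)C(=O)c1ccc(-c2ccc(OS(N)(=O)=O)cc2Cl)o1` gives 27 nM. The two measured steps, a 1.1-fold lower number from compound 1 to compound 2 (0.05 log units; within the scatter) and a 1.0-fold lower number from compound 1 to compound 3 (0.02 log units; within the scatter), each add a chloro on an aromatic carbon of the ring bearing the sulfamate and leave this assay unmoved. Compound 4 `Cc1cc(F)ccc1N(C)C(=O)c1ccc(-c2ccc(OS(N)(=O)=O)cc2)o1` differs from compound 1 by fluoro in place of hydrogen on an aromatic carbon, taking the 2-methylphenyl to 4-fluoro-2-methylphenyl. Within the data shown here, no measured step touches that ring, so the chloro steps bear only loosely on this change, hinting that a halogen on an aromatic carbon of this core shifts nothing beyond the scatter. Compound 4 is therefore expected to show no change at the digits printed from compound 1 to compound 4 (within the scatter), an estimate of 28 nM with a range from 14 nM to 56 nM.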

Compound 4, half-maximal inhibitory concentration: 14 nM
For compound 4 the middle estimate is 2.0-fold (0.30 log units) above the measured one; the range from low to high includes it.
By their numbers in this assay, from the lowest: compounds 4, 2, 3 and 1 (each within the scatter of the next).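

Compound 4 carries the only change shown on the 2-methylphenyl ring, and fluoro at this place, para to the large group, gives a 2.0-fold lower number from compound 1 to compound 4 (0.30 log units; within the scatter) in this assay. So this ring takes a fluoro without a step beyond the scatter, as the ring bearing the sulfamate took chloro. Nothing at hand bears on what lies behind this step.

Open, as far as these compounds go, is whether a larger group here, such as a methoxy or an amine, would move the number beyond the scatter. Also open, from the compounds shown here alone, is how fluoro behaves elsewhere on this ring.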